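This account rests on a few compounds, and the source may have more. Where it says the series, first, only, none or still open, it means among the compounds named here.

Measured compounds:
- compound 1, `COC(=O)c1cc(-c2cccc(NC(=O)c3ccc(/C=C/C(=O)c4ccccc4Br)cc3)c2)on1`: > 40 ug/mL
- compound 2, `CCOC(=O)c1nnn(-c2cccc(NC(=O)c3ccc(/C=C/C(=O)c4ccc(Cl)cc4)cc3)c2)c1C`: "not determined" (no result reported)
- compound 3, `CCCOc1ccc(C(=O)/C=C/c2ccc(C(=O)O)cc2)cc1`: < 10 ug/mL

The account follows the step from compound 1 to compound 4. In an ADME assay on Vero cells (Chlorocebus sabaeus) for cytotoxicity, read by MTT assay, with a stated time of 72 h (on this read-out lower numbers stand for higher toxicity in this test and higher numbers for lower toxicity in this test), compound 1 gives > 40 ug/mL, which is a limit of the assay and not a number, so compound 1 stands at the limit of > 40 ug/mL in this assay, at which 1 of the 3 values shown sits. For compound 2 no result in this assay is reported. Compound 3 gives < 10 ug/mL in this assay, again a limit and not a number, so that compound 3 sits at the limit of < 10 ug/mL in this assay, at which 1 of the 3 values shown sits. Among the measured compounds shown here, no step between two compounds that differ in one place is available, so the size of the change from compound 1 to compound 4 has no measured counterpart here.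

Compound 4, `COC(=O)c1cc(-c2cccc(NC(=O)c3ccc(/C=C/C(=O)c4ccc(OC)cc4OC)cc3)c2)on1`, differs from compound 1 as follows: 2,4-dimethoxyphenyl in place of 2-bromophenyl on a carbonyl carbon. Since compound 1 sits at the upper limit of this assay and the two compounds share the remainder of their structure, compound 4 is expected to remain near that limit, with no step beyond the scatter; the step expected is a number no higher from compound 1 to compound 4 (the limit leaves the size open). The value estimated for compound 4 in this assay is therefore 40 ug/mL, with a range from 15 ug/mL to 80 ug/mL, and it is likely that only a limit is again reported.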

Compound 4, half-maximal cytotoxic concentration: > 50 ug/mL
Compound 4: only a limit was reported; the forecaster's own chance of this, stated with the estimate: 65%; middle value at least 1.2-fold (0.09 log units) away from the limit.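

In this assay compound 1 gives > 40 ug/mL, which is a limit and not a number. Compound 4 gives > 50 ug/mL, again a limit, so no step can be read between these two compounds. The compounds shown leave open how far 2,4-dimethoxyphenyl in place of 2-bromophenyl on a carbonyl carbon shifts the half-maximal cytotoxic concentration, or in which direction.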